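A few compounds are considered here, and "the series" means these few. Any claim that something is new, unique, unknown or untested is made for them only; others in the source may bear on it.

Measured so far in a functional assay on PC-3 cells (Homo sapiens) for cytotoxicity, read by MTT assay; on this read-out lower numbers stand for stronger inhibition and higher numbers for weaker inhibition:
- compound 1 `COc1ccc2cc([C@H](C)c3nnc(SCc4ccc(Cl)cc4)n3-c3ccc(F)cc3)ccc2c1`: <= 400000 nM
- compound 2 `COc1ccc(CSc2nnc([C@@H](C)c3ccc4cc(OC)ccc4c3)n2-c2ccc(Cl)cc2)cc1`: <= 400000 nM

Compound 2 stands at <= 400000 nM, which is a limit of this assay and not a number. The same holds for compound 1, so the data offer the limit of <= 400000 nM in this assay, at which 2 of the 2 values shown sit, and no exact reading.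

Compound 3 `COc1cccc(CSc2nnc([C@@H](C)c3ccc4cc(OC)ccc4c3)n2-c2ccc(Cl)cc2)c1` has the same atoms as compound 2, joined differently: 3-methoxyphenyl in place of 4-methoxyphenyl on a saturated chain carbon bound to a sulfur. Here 3-methoxyphenyl stands in place of 4-methoxyphenyl on a saturated chain carbon bound to a sulfur.

Among the compounds with values here, no measured step shows what such a move does, so no change beyond the usual scatter is expected in this assay, in either direction. The expected step that the limit leaves unreadable from compound 2 to compound 3 therefore stays within that scatter. Compound 3 is estimated at 250000 nM, with an expected range of 60000 nM to 400000 nM.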

Compound 3, half-maximal inhibitory concentration: 138000 nM
Compound 3: middle estimate off by 1.8-fold (0.26 log units), on the high side, and the stated range covers the measured number.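

No step from compound 2 to compound 3 can be read in this assay, because the reading for compound 2 is a limit of the assay and not a number: the limit of <= 400000 nM in this assay, at which 2 of the 3 values shown sit.

The compounds shown leave open whether 3-methoxyphenyl in place of 4-methoxyphenyl changes the reading in this assay at all, and if so, in which direction.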